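The source may hold more compounds than are shown below. What is called first, only, known or untested is meant among the compounds shown, and "the series" means these compounds.

Measured compounds:
- compound 1, `COC(=O)c1c(-c2cc3ccccc3oc2=O)nn(-c2ccccc2)c1C(=O)OC`, 35000 nM
- compound 2, `CCOC(=O)c1c(-c2cc3ccccc3oc2=O)nn(-c2ccc(C)c(C)c2)c1C(=O)OCC`, 50000 nM

Both were tested in a functional assay on HeLa cells (Homo sapiens) for cytotoxicity, read by MTT assay, with a stated time of 48 h; on this read-out higher numbers stand for weaker inhibition and lower numbers for stronger inhibition. Of the two numbers, that of compound 1 is the lower, but the gap to compound 2 lies within the usual scatter of such measurements, so the two cannot be told apart on this evidence.

Compound 3, `COC(=O)c1c(-c2cc3ccccc3oc2=O)nn(-c2cccc(F)c2)c1C(=O)OC`, differs from compound 1 in one place: fluoro in place of hydrogen on an aromatic carbon. For the measured compounds named here, no pair of measured compounds shows the effect of this change, so there is nothing to set the size of the step by. With only the two numbers of compound 1 and compound 2, which themselves do not differ beyond the scatter, no step beyond the scatter is expected in either direction from this small addition. The step expected from it is a 1.1-fold lower number from compound 1 to compound 3 (0.04 log units; within the scatter). Compound 3 is accordingly estimated to give 32000 nM in this assay, within a range from 12000 nM to 85000 nM.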

Compound 3, half-maximal inhibitory concentration: 76000 nM
Compound 3: middle estimate off by 2.4-fold (0.38 log units), on the low side; the measured number falls inside the stated range.
By their numbers in this assay, from the lowest: compounds 1, 2 and 3 (each within the scatter of the next, the first and the last beyond it).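

In this assay, for the compounds shown here, the change from phenyl to 3-fluorophenyl gives the only step that can be read here, a 2.2-fold higher number from compound 1 to compound 3 (0.34 log units; beyond the scatter), modest in size but beyond the scatter. The earlier compounds shown here offered no step at all, whereas this one shows that the phenyl group is not indifferent to a single fluoro on this aromatic carbon, and that the change goes towards weaker inhibition. Nothing at hand bears on why the number rises.

On these data alone, it remains open whether this weakening belongs to fluoro itself or would follow any group on the same carbon, as a chloro, a methoxy or an amine there would show. As far as these compounds go, it is also open whether the same step would appear on the core of compound 2.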